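Compound 4: 1,3-thiazol-2-yl in place of thiophen-2-yl

The compounds below may be only part of what the source reports. "The series", "measured", "known", "first", "only" and "open" are said of these compounds alone.

Of the compounds shown here, three with a shared core have been tested in a functional assay on NCI-H460 cells (Homo sapiens) for cytotoxicity, read by MTT assay, with a stated time of 68 h (on this read-out lower numbers stand for stronger inhibition and higher numbers for weaker inhibition), so far. Compound 1 (`O=C(Nc1cccc(-c2ccsc2)c1)C(Cl)Cl`) reads > 50000 nM and that is a limit, not a number. Compound 2 (`O=C(Nc1cccc(-c2ccccn2)c1)C(Cl)Cl`) reads > 50000 nM and that is also a limit. Compound 3 (`O=C(Nc1cccc(-c2cccs2)c1)C(Cl)Cl`) reads > 50000 nM and that too is a limit, so it has no exact place on the scale. All that can be said of its standing is the limit of > 50000 nM in this assay, at which 3 of the 3 values shown sit, and neither of the other two compounds goes against this.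

Compound 4 (`O=C(Nc1cccc(-c2nccs2)c1)C(Cl)Cl`) carries 1,3-thiazol-2-yl in place of thiophen-2-yl (1,3-thiazol-2-yl in place of thiophen-2-yl on an aromatic carbon) on an aromatic carbon of the six-membered ring. The measured steps that bear on this change are a step that the two limits leave unreadable from compound 1 to compound 3 and a step that the two limits leave unreadable from compound 2 to compound 3 and also a step that the two limits leave unreadable from compound 1 to compound 2 so none of them offers a size to carry over.

Because the limit of > 50000 nM in this assay, at which 3 of the 3 values shown sit, holds for compound 1, compound 2 and compound 3 alike, no step beyond the scatter is expected in this assay and any readable step could only point towards stronger inhibition. The expected change is a number no higher from compound 3 to compound 4 (the limit leaves the size open) in this estimate. For compound 4 the estimated value is 50000 nM with an expected range from 25000 nM to 100000 nM and a limit is the likeliest outcome.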

Compound 4, half-maximal inhibitory concentration: > 50000 nM
Compound 4 gave a limit, no number; the forecaster's own chance of this, stated with the estimate: 80%; the middle value lies on the limit itself.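

In this assay compound 4 gives > 50000 nM, and that is a limit. Going by these compounds alone, no step between compound 4 and compound 1, compound 2 or compound 3 can be read, so the standing is unchanged: the limit of > 50000 nM in this assay, at which 4 of the 4 values shown sit. The compounds shown leave open whether any of these four groups on the shared core differs from another in cytotoxicity.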